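The source may hold more compounds than are shown below. What is called first, only, known or untested is meant among the compounds shown, and "the series" means these compounds.

Compound 1 `COc1ccc(-c2nnc(N3CCN(C(=O)CN4CCN(c5ccccc5)CC4)CC3)nc2-c2ccc(OC)cc2)cc1`: in an ADME assay on NIH3T3 cells (Mus musculus) for cytotoxicity, read by MTT assay, with a stated time of 24 h (on this read-out higher numbers stand for weaker inhibition and lower numbers for stronger inhibition), compound 1 gives > 863000 nM, which is a limit of the assay rather than a number.
Compound 2 `COc1ccc(-c2nnc(N3CCN(C(=O)CN4CCN(c5ccccc5Cl)CC4)CC3)nc2-c2ccc(OC)cc2)cc1`: in this assay compound 2 gives > 814000 nM, again only a limit.
Compound 3 `COc1cccc(N2CCN(CC(=O)N3CCN(c4nnc(-c5ccc(Cl)cc5)c(-c5ccc(Cl)cc5)n4)CC3)CC2)c1`: in this assay compound 3 gives 202000 nM.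

Among the measured compounds shown here, compound 3 therefore stands as the one compound with a measured number; the other two values are limits. For the measured compounds named here, the single measured step, a step that the two limits leave unreadable from compound 1 to compound 2, cannot be read because its two ends sit at the limit of > 863000 nM in this assay, at which 1 of the 3 values shown sits, and (the limit of > 814000 nM in this assay, at which 1 of the 3 values shown sits). Compound 4 `O=C(CN1CCN(c2ccc([N+](=O)[O-])cc2)CC1)N1CCN(c2nnc(-c3ccc(Cl)cc3)c(-c3ccc(Cl)cc3)n2)CC1` differs from compound 3 by 4-nitrophenyl in place of 3-methoxyphenyl on an amine nitrogen in a ring. No readable step bears on this change, so no shift beyond the usual scatter is assumed, and the expected step is a 1.0-fold lower number from compound 3 to compound 4 (0.00 log units; within the scatter). Compound 4 is estimated at 200000 nM, with a range from 70000 nM to 600000 nM.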

Compound 4, half-maximal inhibitory concentration: > 789000 nM
Compound 4 ended at the assay's limit; the forecaster's own chance of this, stated with the estimate: 25%; at least 3.9-fold (0.59 log units) between middle value and limit.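

The aryl group on this amine nitrogen in a ring can clearly change the read-out: in this assay the swap gives an at least 3.9-fold higher number from compound 3 to compound 4 (0.59 log units; beyond the scatter) and so means weaker inhibition of the cells. On these data alone, compound 4 gives a limit of the assay, not a number, so the true size of this step stays unknown. The earlier step at this group could not be read, which makes this the first readable change there.

The swap alters both the group and its place on the phenyl ring, and the two effects cannot be separated. As far as these compounds go, how an amine or a carboxylic acid on that phenyl ring would read remains open.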